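A hexyl swap on compound 1

A few compounds are considered here, and "the series" means these few. Any claim that something is new, unique, unknown or untested is made for them only; others in the source may bear on it.

Among the measured compounds shown here, in a functional assay on 2008 cells (Homo sapiens) for inhibition (a lower number here means a stronger inhibitor of growth, a higher number a weaker inhibitor of growth), compound 1 `C=C/C=C\[C@H](C)[C@H](OC(N)=O)[C@@H](C)[C@H](O)CC/C=C\C(C)[C@@H](O)[C@@H](C)/C=C\CC[C@@H]1O[C@@H](OC)[C@H](C)[C@@H](OCOC)[C@@H]1C` gives 4.7 nM, the only actual number among the three compounds tested so far. Compound 2 `COCOC1=C(C)C(=O)O[C@@H](CC/C=C\[C@H](C)[C@H](O)C(C)/C=C\CC[C@@H](O)[C@H](C)[C@@H](OC(N)=O)C(C)C)[C@H]1C` is reported only as a limit, > 50 nM. Compound 3 `COCO[C@H]1[C@@H](C)[C@H](CC/C=C\[C@H](C)[C@H](O)[C@@H](C)/C=C\CC[C@@H](O)[C@H](C)COC(N)=O)OC(=O)[C@@H]1C` is likewise reported only as a limit, > 50 nM. Compound 1 therefore stands alone with a measured value, and no measured step connects any two of these compounds.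

Compound 4 `CCCCCC[C@H](OC(N)=O)[C@@H](C)[C@H](O)CC/C=C\C(C)[C@@H](O)[C@@H](C)/C=C\CC[C@@H]1O[C@@H](OC)[C@H](C)[C@@H](OCOC)[C@@H]1C` keeps the rest of compound 1 but carries hexyl in place of 1-methylpenta-2,4-dien-1-yl on a saturated chain carbon bound to an oxygen next to a carbonyl group and a saturated chain carbon. For the measured compounds named here, with no measured step as a guide, the expectation is a moderate move beyond the scatter towards weaker growth inhibition in this assay, starting from compound 1 at 4.7 nM. The estimated change is a 6.4-fold higher number from compound 1 to compound 4 (0.81 log units; beyond the scatter). The expected value for compound 4 is 30 nM, with an estimated range from 8 nM to 100 nM.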

Compound 4, concentration for 50% growth inhibition: 29 nM
For compound 4 the middle estimate is 1.0-fold (0.01 log units) above the measured one; the range from low to high includes it.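

In this assay, among the compounds shown here, putting hexyl in place of 1-methylpenta-2,4-dien-1-yl gives the first measured step in this set, a 6.2-fold higher number from compound 1 to compound 4 (0.79 log units; beyond the scatter), so the potency of this series responds to the group on this saturated chain carbon. The swap keeps the count of heavy atoms but removes both double bonds and the defined stereocentre of the group, and growth inhibition weakens without being lost, as compound 4 gives 29 nM. Compound 4 thus gives an actual number rather than a limit, the form taken by two of the values shown: the limit of > 50 nM in this assay, at which 2 of the 4 values shown sit.

This single step cannot separate the loss of the double bonds from the loss of the methyl branch. Going by these compounds, how a butyl chain, a phenyl group or an amine would read at this place remains open.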